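The compounds below may be only part of what the source reports. "The series", "measured", "known", "first", "only" and "open" are said of these compounds alone.

Measured so far in an ADME assay for permeability, using PAMPA, with a stated time of 4 h, at pH 7.4; on this read-out higher numbers stand for higher permeability and lower numbers for lower permeability
compound 1 `c1ccc2c(c1)CN[C@H](CN(CCCN1CCNCC1)[C@H]1CCCc3cccnc31)C2` gives 16 nm/s
compound 2 `c1cnc2c(c1)CCC[C@@H]2N(CCCN1CCNCC1)Cc1cc2ccccc2cn1` gives 243 nm/s
compound 3 `CN1CCN(CCCN(C[C@H]2Cc3ccccc3CN2C)[C@H]2CCCc3cccnc32)CC1` gives 513 nm/s

Compound 2 at 243 nm/s stands second highest of the three, with compound 3 at 513 nm/s above it and compound 1 at 16 nm/s far below it. Both gaps lie beyond the scatter.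

The unmeasured compound 4 `c1cnc2c(c1)CN[C@@H](CN(CCCN1CCNCC1)[C@H]1CCCc3cccnc31)C2` differs from compound 2 in one place (a group of 10 heavy atoms (8 carbon, 2 nitrogen; one six-membered non-aromatic ring with 1 hetero atom, one six-membered aromatic ring with 1 hetero atom) in place of a group of 10 heavy atoms (9 carbon, 1 nitrogen; one six-membered aromatic ring of carbon only, one six-membered aromatic ring with 1 hetero atom), on a saturated chain carbon bound to an amine nitrogen) on a saturated chain carbon bound to an amine nitrogen. The entering group holds one six-membered non-aromatic ring with 1 hetero atom where isoquinolin-3-yl holds one six-membered aromatic ring of carbon only, which puts it closer to the 1,2,3,4-tetrahydroisoquinolin-3-yl of compound 1.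

Going by the values given here, one measured step bears on this change: a 15-fold higher number from compound 1 to compound 2 (1.18 log units; beyond the scatter) for isoquinolin-3-yl in place of 1,2,3,4-tetrahydroisoquinolin-3-yl at that same place. It is large and beyond the scatter. Among the compounds with values here, compound 3 is joined to the others by no single-place step and gives no measure of the change. Within the data shown here, no measured compound carries the entering group itself, so the expectation rests on that one step read in reverse, which points to a large drop in this assay from the level of compound 2.

The expected step is a 20-fold lower number from compound 2 to compound 4 (1.31 log units; beyond the scatter) in this estimate.
The estimated value for compound 4 is 12 nm/s with an expected range from 4 nm/s to 40 nm/s as the working figure.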

Compound 4, apparent permeability: 9 nm/s
For compound 4 the middle estimate is 1.3-fold (0.12 log units) above the measured one; measured number inside the range.
By their numbers in this assay, from the lowest: compounds 4 and 1 (each within the scatter of the next); then compound 2; then compound 3.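

At this place, on a saturated chain carbon bound to an amine nitrogen, the second group with a six-membered non-aromatic ring gives a large step in this assay: a 27-fold lower number from compound 2 to compound 4 (1.43 log units; beyond the scatter). The earlier compounds shown here showed this contrast for one such group only, and it now holds for two. The nitrogen in the aromatic ring of the entering group sets it apart from 1,2,3,4-tetrahydroisoquinolin-3-yl, yet that swap gives only a 1.8-fold lower number from compound 1 to compound 4 (0.25 log units; within the scatter), so among these three compounds the large gap separates isoquinolin-3-yl from both groups with the non-aromatic ring. No measurement shown gives a reason for either step.

A fully aromatic naphthyridinyl group at this place would test whether the extra ring nitrogen matters once the non-aromatic ring is absent, and the compounds shown offer no such pair. As far as these compounds go, how a smaller group such as phenyl or pyridin-3-yl would compare with isoquinolin-3-yl at this place also stays open, as does whether these steps carry over to the methylated piperazine side chain of compound 3.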